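A Chain Gives Way to a Bromophenyl Group

A few compounds are considered here, and "the series" means these few. Any claim that something is new, unique, unknown or untested is made for them only; others in the source may bear on it.

Compound 1 `C=C1CC[C@@H]2[C@](C)(CO)[C@H](O)CC[C@@]2(C)[C@@H]1/C=C/C1=C/C(=C/c2ccco2)OC1=O`: 100000 nM
Compound 2 `C=C1CC[C@@H]2[C@](C)(COC(=O)c3cccnc3)[C@H](OC(=O)c3cccnc3)CC[C@@]2(C)[C@@H]1/C=C/C1=C/C(=C\C(C)=C\CCC/C=C/C)OC1=O`: 28000 nM

Both of these were tested in an assay on isolated protein for inhibition of Maltase-glucoamylase (Homo sapiens); a higher number here means a weaker inhibitor, a lower number a stronger inhibitor. Of the two numbers, compound 2 has the lower one, and compound 1 stands above it by a gap beyond the usual scatter, so compound 2 is the stronger inhibitor of the pair. Compound 3 `C=C1CC[C@@H]2[C@](C)(COC(=O)c3cccnc3)[C@H](OC(=O)c3cccnc3)CC[C@@]2(C)[C@@H]1/C=C/C1=C/C(=C\c2cccc(Br)c2)OC1=O` is built from compound 2 by one change: a group of 7 heavy atoms (6 carbon, 1 bromine; one six-membered aromatic ring of carbon only) in place of a group of 9 heavy atoms (9 carbon; no ring), on a double-bonded chain carbon bound to a double-bonded ring carbon. For the measured compounds named here, no measured pair shows this kind of swap on its own. Compound 1 does carry a ring at the same place, but it also differs from compound 2 elsewhere, so it cannot separate the two effects. For compound 3 the expectation is therefore a step of a 1.3-fold higher number from compound 2 to compound 3 (0.10 log units; within the scatter) that stays within the scatter, with no clear direction. The estimated value for compound 3 in this assay is 35000 nM, with a likely range from 10000 nM to 100000 nM.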

Compound 3, half-maximal inhibitory concentration: 14000 nM
Compound 3: middle estimate off by 2.5-fold (0.40 log units), on the high side; the range from low to high includes it.
By their numbers in this assay, from the lowest: compounds 3 and 2 (each within the scatter of the next); then compound 1.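

In this assay, replacing the open chain of 9 heavy atoms with 3-bromophenyl gives a 2.0-fold lower number from compound 2 to compound 3 (0.30 log units; within the scatter) and so leaves the inhibition unchanged within the scatter. For the compounds shown here, this is the first clean look at this position, on a double-bonded chain carbon bound to a double-bonded ring carbon: compound 1 also carries a ring here but differs elsewhere, whereas compound 3 shows that a long ring-free chain and a six-membered aromatic ring can stand in the same place with no change beyond the scatter. No measurement here explains why the two groups give such similar results.

As far as these compounds go, whether the bromine contributes anything remains open, since a plain phenyl group would be needed to test it. It is also unknown how this position would respond to a ring carrying an amine or a carboxylic acid.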